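Swapping the benzyl group on a shared core

This account rests on a few compounds, and the source may have more. Where it says the series, first, only, none or still open, it means among the compounds named here.

Compound 1 `NC1CCC(Nc2nc(NCc3ccc(-n4cccn4)cc3)c3ncn(C4CCCC4)c3n2)CC1` 320 nM
Compound 2 `NC1CCC(Nc2nc(NCc3ccc(-c4ccsc4)nc3)c3ncn(C4CCCC4)c3n2)CC1` 145 nM
Compound 3 `NC1CCC(Nc2nc(NCc3cc(Cl)ccc3O)c3ncn(C4CCCC4)c3n2)CC1` 350 nM

In a functional assay on HCT-116 cells (Homo sapiens) for inhibition, with a stated time of 72 h (a higher number here means a weaker inhibitor, a lower number a stronger inhibitor), compound 3 stands at 350 nM. The measurements show a 1.1-fold higher number from compound 1 to compound 3 (0.04 log units; within the scatter), and also a 2.4-fold higher number from compound 2 to compound 3 (0.38 log units; beyond the scatter). Compound 4 `Nc1ccccc1CNc1nc(NC2CCC(N)CC2)nc2c1ncn2C1CCCC1` carries 2-aminophenyl in place of 5-chloro-2-hydroxyphenyl on a saturated chain carbon bound to a nitrogen on an aromatic ring. Among the measured compounds shown here, no measured step makes this exact exchange. Other exchanges at this place stayed modest, the third being a 2.2-fold lower number from compound 1 to compound 2 (0.34 log units; beyond the scatter). No change beyond the scatter is therefore expected in this assay, and the expected step is a 1.1-fold higher number from compound 3 to compound 4 (0.04 log units; within the scatter). Compound 4 is estimated at 380 nM, with an expected range of 140 nM to 1000 nM.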

Compound 4, half-maximal inhibitory concentration: 2300 nM
Compound 4: the middle estimate sits 6.1-fold (0.78 log units) below what was measured, outside the stated range (above it).
By their numbers in this assay, from the lowest: compound 2; then compounds 1 and 3 (each within the scatter of the next); then compound 4.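

In this assay the 2-aminobenzyl group opens the first wide gap at this position, with a 6.6-fold higher number from compound 3 to compound 4 (0.82 log units; beyond the scatter) and a 7.2-fold higher number from compound 1 to compound 4 (0.86 log units; beyond the scatter) and even a 16-fold higher number from compound 2 to compound 4 (1.20 log units; beyond the scatter) in the same direction. So the group on this saturated chain carbon can shift the number far more than the earlier exchanges did, although the 5-chloro-2-hydroxyphenyl and 2-aminophenyl groups count the same hydrogen-bond donors and acceptors. Nothing available accounts for this step.

From the compounds shown here alone, compound 3 and compound 4 differ at once in the chlorine and in hydroxyl against amine, so which of these carries the step stays open. A plain benzyl group would offer a reference for both.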